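A Second Aryl Swap on the Ring Nitrogen

This account rests on a few compounds, and the source may have more. Where it says the series, first, only, none or still open, it means among the compounds named here.

Within the data shown here, compound 2 `O=C(/C=C/c1ccccc1)c1ccc(N2CCN(c3ccccc3Cl)CC2)cc1` was tested in a functional assay on the whole organism (strain Kunming) for inhibition, with Mus musculus as the target, with a stated time of 1 h, at a dose of 40 mg/kg by the oral route (on this read-out lower numbers stand for less inhibition and higher numbers for more inhibition at the one dose given (going by the name of the read-out)), where compound 2 gives 4.71%, the lowest of the two numbers measured so far. Among the measured compounds shown here, its only neighbour is compound 1 `O=C(/C=C/c1ccccc1)c1ccc(N2CCN(c3ccc([N+](=O)[O-])cc3)CC2)cc1`, which in this assay gives 55.4%; the step of a number 50.7 percentage points lower from compound 1 to compound 2 (beyond the scatter) is large and came with a 2-chlorophenyl in place of a 4-nitrophenyl on the amine nitrogen in the ring. Compound 3 `O=C(/C=C/c1ccccc1)c1ccc(N2CCN(c3cccc(C(F)(F)F)c3)CC2)cc1` has not yet been measured. It differs from compound 2 by 3-(trifluoromethyl)phenyl in place of 2-chlorophenyl on an amine nitrogen in a ring. For the measured compounds named here, only the single step from compound 1 to compound 2 bears on this change, and it shows that exchanging the aryl group on that nitrogen can move the read-out a great deal; no measured step involves a 3-(trifluoromethyl)phenyl. The expectation for compound 3 is therefore a rise from a low starting point, a number 20.3 percentage points higher from compound 2 to compound 3 (beyond the scatter), with wide uncertainty. Compound 3 is estimated to give 25%, between 2% and 55%.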

Compound 3, a percentage reported as inhibition, in the whole organism at one dose (the size of the read-out at that dose, not a potency): 25%
Estimate against measurement, compound 3: no gap at the digits printed, within the range that was stated.
By their numbers in this assay, from the lowest: compound 2; then compound 3; then compound 1.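

With a third aryl group on the amine nitrogen in the ring, this assay shows that this position gives more than a high and a low result: 3-(trifluoromethyl)phenyl in place of 2-chlorophenyl gives a number 20.3 percentage points higher from compound 2 to compound 3 (beyond the scatter), while the same group in place of 4-nitrophenyl gives a number 30.4 percentage points lower from compound 1 to compound 3 (beyond the scatter). The three aryl groups therefore sit at three separate levels on the shared core, with compound 1 highest, as its steps to both others lie beyond the scatter. Nothing measured here speaks to the reason for this order.

As far as these compounds go, it remains open whether the order follows the kind of substituent or its place on the phenyl ring, as the three compounds change both at once. An unsubstituted phenyl or a methoxy-bearing phenyl on the same nitrogen would be a further point of comparison.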